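Fluoro Added to a Second Position of the Shared Core

A few compounds are considered here, and "the series" means these few. Any claim that something is new, unique, unknown or untested is made for them only; others in the source may bear on it.

Of the compounds shown here, three with a shared core have been measured in an ADME assay on HEp-2 cells (Homo sapiens) for cytotoxicity, read by CCK-8 assay, with a stated time of 5 days; a lower number here means that less compound is tolerated, a higher number that more compound is tolerated. Compound 1 `NCCNc1cc(N2CCCc3ccccc3C2)nc2ccccc12` gives 23000 nM. Compound 2 `Cc1ccc2nc(N3CCCc4ccccc4C3)cc(NCCN)c2c1` gives 9400 nM. Compound 3 `NCCNc1cc(N2CCCc3ccccc3C2)nc2ccc(F)cc12` gives 8000 nM. The step of a 2.4-fold lower number from compound 1 to compound 2 (0.39 log units; beyond the scatter) comes from methyl in place of hydrogen on an aromatic carbon, and the step of a 2.9-fold lower number from compound 1 to compound 3 (0.46 log units; beyond the scatter) comes from fluoro in place of hydrogen on an aromatic carbon. Between compound 2 and compound 3 the step of a 1.2-fold lower number from compound 2 to compound 3 (0.07 log units; within the scatter) stays inside the usual scatter, so no order between them can be read.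

Compound 4 `Cc1ccc2nc(N3CCCc4ccc(F)cc4C3)cc(NCCN)c2c1` is not yet measured. It differs from compound 2 by fluoro in place of hydrogen on an aromatic carbon. The change from compound 1 to compound 3 is the same change, and it made the step of a 2.9-fold lower number from compound 1 to compound 3 (0.46 log units; beyond the scatter). Compound 2 already stands lower than compound 1, so the same change on compound 2 is expected to give a step of about a 1.9-fold lower number from compound 2 to compound 4 (0.27 log units; within the scatter) in this assay, resting on the step of a 2.9-fold lower number from compound 1 to compound 3 (0.46 log units; beyond the scatter) seen once before. Compound 4 is therefore expected to give about 5000 nM, with a range from 2500 nM to 12000 nM.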

Compound 4, half-maximal cytotoxic concentration: > 3200 nM
Compound 4: only a limit was reported; the forecaster's own chance of this, stated with the estimate: 5%; the middle value is on the limit's open side.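

In this assay compound 4 gives > 3200 nM, which is a limit and not a number. No size can be read for the step from compound 2 to compound 4. The compounds shown leave open whether fluoro in place of hydrogen on compound 2 changes how much compound is tolerated, and in which direction.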